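A few compounds are considered here, and "the series" means these few. Any claim that something is new, unique, unknown or untested is made for them only; others in the source may bear on it.

Compound 1 `CC(C)(C)NC(=O)Oc1ccc(C2=NCCS2)cc1` gives 7000 nM in an assay on cell membranes (strain Wistar) for inhibition of Fatty-acid amide hydrolase 1 (Rattus norvegicus), read by scintillation counting; a lower number here means a stronger inhibitor, a higher number a weaker inhibitor.
Compound 2 `O=C(NC1CCCCC1)Oc1ccc(C2=NCCS2)cc1` gives 100 nM.
Compound 3 `O=C(NCc1ccccc1)Oc1ccc(C2=NCCS2)cc1` gives 290 nM.

Compound 3 stands second of the three in this assay: there is a 2.9-fold higher number from compound 2 to compound 3 (0.46 log units; beyond the scatter), and there is a 24-fold lower number from compound 1 to compound 3 (1.38 log units; beyond the scatter). Compound 4 `Cc1ccccc1CNC(=O)Oc1ccc(C2=NCCS2)cc1` differs from compound 3 only by methyl in place of hydrogen on an aromatic carbon. Within the data shown here, none of the measured steps alters this position. The three steps, a 70-fold lower number from compound 1 to compound 2 (1.85 log units; beyond the scatter), a 24-fold lower number from compound 1 to compound 3 (1.38 log units; beyond the scatter) and a 2.9-fold higher number from compound 2 to compound 3 (0.46 log units; beyond the scatter), each exchange the whole group on the amide-type nitrogen, and they show that this assay answers strongly to what that group is. A single methyl on the phenyl of the benzyl group is a much smaller alteration than any of those exchanges, so only a small effect is anticipated, and its direction cannot be read from the measured compounds. Compound 4 is therefore expected to give about 250 nM in this assay, within a range from 80 nM to 800 nM. For compound 4 this expectation amounts to a 1.2-fold lower number from compound 3 to compound 4 (0.06 log units; within the scatter), a step not expected to exceed the scatter.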

Compound 4, half-maximal inhibitory concentration: 62 nM
Beside the measured number, compound 4's estimate is 4.0-fold (0.61 log units) above it; the measured number lies below the stated range.
By their numbers in this assay, from the lowest: compounds 4 and 2 (each within the scatter of the next); then compound 3; then compound 1.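

Until this point only whole groups on the amide-type nitrogen had been exchanged; the change from phenyl to 2-methylphenyl, a single carbon placed ortho to a large group, gives a 4.7-fold lower number from compound 3 to compound 4 (0.67 log units; beyond the scatter) in this assay, so the aromatic ring of the benzyl group is itself a place to which the read-out responds. With this methyl, compound 4 stands within the scatter of compound 2, so a substituted benzyl group reaches the level of the cyclohexyl group. Nothing given here explains the step.

Whether the gain belongs to methyl itself or to its place stays open, since the compounds shown include no methoxy, chloro or trifluoromethyl group on this ring and no methyl elsewhere on it. From the compounds shown here alone, a longer chain between the nitrogen and the phenyl ring also remains open.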